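A few compounds are considered here, and "the series" means these few. Any claim that something is new, unique, unknown or untested is made for them only; others in the source may bear on it.

In a functional assay on MCF7 cells (Homo sapiens) for inhibition, with a stated time of 96 h (a lower number here means a stronger inhibitor, a higher number a weaker inhibitor), compound 1 `COc1cc(C(=O)c2cn(-c3cccc(C)c3)cc2-c2ccco2)cc(OC)c1OC` gives 23 nM, compound 2 `COc1cc(C(=O)c2cn(-c3cccc(C)c3)cc2-c2ncco2)cc(OC)c1OC` gives 75 nM, and compound 3 `COc1cc(C(=O)c2cn(-c3cccc(C)c3)cc2-c2cccnc2)cc(OC)c1OC` gives 52 nM. Compound 3 therefore sits within the scatter of its nearest neighbour, with a 1.4-fold lower number from compound 2 to compound 3 (0.16 log units; within the scatter), but is a weaker inhibitor on a 2.3-fold higher number from compound 1 to compound 3 (0.35 log units; beyond the scatter). Compound 4 `COc1cc(C(=O)c2cn(-c3cccc(C)c3)cc2-c2ccncc2)cc(OC)c1OC` has the same atoms, joined differently: pyridin-4-yl in place of pyridin-3-yl on an aromatic carbon. Going by the values given here, no measured step compares two pyridinyl groups, so the nearest guides are the other ring swaps at this place. There, a 3.3-fold higher number from compound 1 to compound 2 (0.51 log units; beyond the scatter) was modest, and the swap between compound 2 and compound 3 stayed within the scatter. A small change in either direction is expected, estimated as a 1.2-fold higher number from compound 3 to compound 4 (0.06 log units; within the scatter). Compound 4 is estimated at 60 nM, with an expected range from 25 nM to 145 nM.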

Compound 4, half-maximal inhibitory concentration: 65 nM
The estimate for compound 4 lay 1.1-fold (0.03 log units) below the measured number; the measured number falls inside the stated range.
By their numbers in this assay, from the lowest: compound 1; then compounds 3, 4 and 2 (each within the scatter of the next).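

In this assay, pyridin-4-yl and pyridin-3-yl cannot be told apart (a 1.3-fold higher number from compound 3 to compound 4 (0.10 log units; within the scatter)), and neither can pyridin-4-yl and 1,3-oxazol-2-yl (a 1.2-fold lower number from compound 2 to compound 4 (0.06 log units; within the scatter)). Furan-2-yl still gives the stronger inhibitor, this time against pyridin-4-yl (a 2.8-fold higher number from compound 1 to compound 4 (0.45 log units; beyond the scatter)), so its edge now holds against all three other rings shown at this position. No evidence here gives a reason for this pattern. From the compounds shown here alone, it remains open whether pyridin-2-yl, thiophen-2-yl or a plain phenyl group at this position would match furan-2-yl.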